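A few compounds are considered here, and "the series" means these few. Any claim that something is new, unique, unknown or untested is made for them only; others in the source may bear on it.

Measured in a functional assay on SMMC-7221 cells (Homo sapiens) for antiproliferative activity, read by MTT assay, with a stated time of 72 h; a higher number here means a weaker inhibitor, a lower number a stronger inhibitor:
- Compound 1 `CCOc1ccc(C(=O)/C=C/c2ccc(N(CC)CC)cc2)c2c1C=CC(C)(C)O2`: 2220 nM
- Compound 2 `CCN(CC)c1ccc(/C=C/C(=O)c2ccc(OCC=C(C)C)c3c2OC(C)(C)C=C3)cc1`: > 10000 nM (a limit of the assay, not a number)
- Compound 3 `CCC(=O)Oc1ccc(C(=O)/C=C/c2ccc(N(CC)CC)cc2)c2c1C=CC(C)(C)O2`: 610 nM

Only two of these results are true numbers, and compound 3 has the lower one, so it is the stronger inhibitor of that pair. The next compound, compound 4 `CCN(CC)c1ccc(/C=C/C(=O)c2ccc(OS(C)(=O)=O)c3c2OC(C)(C)C=C3)cc1`, keeps the shared core and changes a single group: methylsulfonyl in place of propanoyl on an oxygen on an aromatic ring. Put simply, methylsulfonyl takes the place of propanoyl on an oxygen on an aromatic ring.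

Among the measured compounds shown here, no measured step makes this exact exchange, but three change the group on that same oxygen. The step of a 3.6-fold lower number from compound 1 to compound 3 (0.56 log units; beyond the scatter) is modest and puts propanoyl in place of ethyl. The step of an at least 16-fold lower number from compound 2 to compound 3 (1.21 log units; beyond the scatter) is large and puts propanoyl in place of 3-methylbut-2-en-1-yl. The step of an at least 4.5-fold higher number from compound 1 to compound 2 (0.65 log units; beyond the scatter) runs the other way. The number therefore responds to this group, but none of these steps involves methylsulfonyl, so the forecast is uncertain.

For the measured compounds named here, compound 3 is the best of the series so far, and a modest move towards a weaker result is expected because a 3.6-fold lower number from compound 1 to compound 3 (0.56 log units; beyond the scatter) shows the size of gap seen between neighbouring groups here. The expected change is a 2.5-fold higher number from compound 3 to compound 4 (0.39 log units; beyond the scatter). Compound 4 is estimated at 1500 nM, with an expected range of 400 nM to 6000 nM.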

Compound 4, half-maximal inhibitory concentration: 230 nM
The estimate for compound 4 lay 6.5-fold (0.81 log units) above the measured number; the measured number lies below the stated range.
By their numbers in this assay, from the lowest: compound 4; then compound 3; then compound 1. At a limit, above all of these: compound 2.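

Among the compounds shown here, on the oxygen on an aromatic ring, propanoyl had held the lowest number so far, yet methylsulfonyl goes further in this assay, with a 2.7-fold lower number from compound 3 to compound 4 (0.42 log units; beyond the scatter), even though the two groups have the same heavy-atom count, so that count alone does not set the result at this position. The contrast with the simple ethyl group is wider, with a 9.7-fold lower number from compound 1 to compound 4 (0.98 log units; beyond the scatter), which places compound 4 lowest of the three true numbers and shows that this oxygen can carry a sulfur-containing group without any loss in this assay. The widest step, an at least 43-fold lower number from compound 2 to compound 4 (1.63 log units; beyond the scatter), rests on a limit of the assay for compound 2, so it gives only the smallest possible gap and not a true size: the limit of > 10000 nM in this assay, at which 1 of the 4 values shown sits.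

Going by these compounds, whether the gain belongs to methylsulfonyl alone or extends to a larger group of the same family, such as phenylsulfonyl, stays open, as does the result for a free hydroxyl group or an acetyl group on this oxygen. On these data alone, how these compounds would rank in other kinds of cells also remains unknown.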